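A few compounds are considered here, and "the series" means these few. Any claim that something is new, unique, unknown or untested is made for them only; others in the source may bear on it.

Measured so far:
compound 1, `CCCNc1nc(-c2ccccc2)nc2c1nnn2Cc1ccccc1`, 37000000 nM;
compound 2, `CCNc1nc(-c2ccccc2)nc2c1nnn2Cc1ccccc1`, 91000000 nM.

Going by the values given here, in an assay on isolated protein for binding affinity to adenosine receptor A1 (Bos taurus) (on this read-out higher numbers stand for weaker inhibition and lower numbers for stronger inhibition), compound 2 holds the highest of the two numbers, with compound 1 as its only neighbour. Among the compounds with values here, the step of a 2.5-fold higher number from compound 1 to compound 2 (0.39 log units; beyond the scatter) is the one measured step that bears on the change at hand. Compound 3, `c1ccc(Cn2nnc3c(NC4CC4)nc(-c4ccccc4)nc32)cc1`, differs from compound 2 by cyclopropyl in place of ethyl on a nitrogen on an aromatic ring. As the shortening of the chain from compound 1 to compound 2 raised the number, a modest drop from compound 2 to compound 3 is expected, roughly a 2.0-fold lower number from compound 2 to compound 3 (0.31 log units; beyond the scatter). Compound 3 is therefore estimated at 45000000 nM, in the range 15000000 nM to 150000000 nM.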

Compound 3, inhibition constant: 11000000 nM
Compound 3: middle estimate off by 4.1-fold (0.61 log units), on the high side; measured number outside the range, below it.
By their numbers in this assay, from the lowest: compound 3; then compound 1; then compound 2.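

In this assay, the cyclopropyl group on this nitrogen goes beyond the effect of chain length seen so far, with an 8.3-fold lower number from compound 2 to compound 3 (0.92 log units; beyond the scatter) for cyclopropyl in place of ethyl. It also beats the longer open chain, with a 3.4-fold lower number from compound 1 to compound 3 (0.53 log units; beyond the scatter) for cyclopropyl in place of propyl, so among these three groups the ring gives the lowest number. Nothing available explains this difference.

The compounds shown leave open whether a larger ring such as cyclobutyl or cyclopentyl would lower the number further. They also leave open whether a branched chain such as isopropyl would do the same as the cyclopropyl ring.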